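Ring nitrogen substituent: from compound 2 to compound 3

The compounds below may be only part of what the source reports. "The series", "measured", "known", "first", "only" and "open" are said of these compounds alone.

Compound 1 `Cc1ccc(C2=NNC(c3cn(-c4ccccc4)nc3-c3ccc(Cl)c(Cl)c3)C2)cc1` gives 56.5% in a functional assay on the whole organism (strain Wistar) for inhibition, with Rattus norvegicus as the target, read by paw edema, with stated times of 30 min and 60 min, at a dose of 50 mg/kg by the oral route; a higher number here means more inhibition at the dose given (going by the name of the read-out), a lower number less inhibition. Compound 2 `Cc1ccc(C2=NN(C=O)C(c3cn(-c4ccccc4)nc3-c3ccc(Cl)c(Cl)c3)C2)cc1` carries formyl in place of hydrogen on an amine nitrogen in a ring and gives 53.4% in this assay; the step of a number 3.1 percentage points lower from compound 1 to compound 2 (within the scatter) lies within the scatter. On the two numbers shown, compound 2 has the lowest of the two, with compound 1 nearest, but the gap is within the scatter, so the two read as equivalent.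

Compound 3 `Cc1ccc(C2=NN(c3ccccc3)C(c3cn(-c4ccccc4)nc3-c3ccc(Cl)c(Cl)c3)C2)cc1` differs from compound 2 by phenyl in place of formyl on an amine nitrogen in a ring. Among the measured compounds shown here, the only measured step at this nitrogen, a number 3.1 percentage points lower from compound 1 to compound 2 (within the scatter), stayed within the scatter; no measured step covers phenyl at this position. The expectation is therefore no step beyond the scatter in this assay, and a number 0.4 percentage points lower from compound 2 to compound 3 (within the scatter) is the estimated change. Compound 3 is estimated at 53%, with a range from 38% to 68%.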

Compound 3, a percentage reported as inhibition, in the whole organism at one dose (the size of the read-out at that dose, not a potency): 58.8%
For compound 3 the middle estimate is 5.8 percentage points below the measured one, and the stated range covers the measured number.
By their numbers in this assay, from the lowest: compounds 2, 1 and 3 (each within the scatter of the next).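

In this assay the steps of a number 5.4 percentage points higher from compound 2 to compound 3 (within the scatter) and a number 2.3 percentage points higher from compound 1 to compound 3 (within the scatter) extend what this amine nitrogen in a ring accepts from formyl to phenyl, a six-membered aromatic ring of carbon only with no hydrogen-bond acceptor. Hydrogen, formyl and phenyl at this nitrogen therefore read as equivalent at this single dose, so neither the acceptor of the formyl nor the added ring of the phenyl goes with a step beyond the scatter. No evidence is available to explain this flat response.

Open, going by these compounds, is whether a benzyl group, a longer alkyl chain or a phenyl bearing a carboxylic acid at this nitrogen would move the number beyond the scatter. One dose also leaves open whether these compounds would still read as equivalent at other doses.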